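Piperidine in place of thiomorpholine on a thiosemicarbazone core

The compounds below may be only part of what the source reports. "The series", "measured", "known", "first", "only" and "open" are said of these compounds alone.

Measured so far:
compound 1, `Cc1cccc(/C(N)=N/NC(=S)N2CCSCC2)n1`: 67.6%
compound 2, `Cc1ccnc(/C(N)=N/NC(=S)N2CCN(c3ccccn3)CC2)c1`: 49.2%
compound 3, `Cc1ccnc(/C(N)=N/NC(=S)N2CCSCC2)c1`: 39.2%

In a functional assay on HeLa cells (Homo sapiens) for cytotoxicity, read by MTT assay, with a stated time of 72 h, tested at 10 uM (a higher number here means more inhibition of growth at the concentration tested, a lower number less inhibition of growth), compound 1 gives the highest of the three numbers. Compound 2 lies closest, with a number lower by a margin beyond the usual scatter, and compound 3 lies furthest, also beyond the scatter. Compound 4, `Cc1cccc(/C(N)=N/NC(=S)N2CCCCC2)n1`, has not been measured. It differs from compound 1 by piperidin-1-yl in place of thiomorpholin-4-yl on a thiocarbonyl carbon. Among the measured compounds shown here, no measured pair in this set shows what such a change does, so the expectation rests on compound 1 alone. In this assay a step from compound 1 to compound 4 of about a number 7.6 percentage points lower from compound 1 to compound 4 (within the scatter) is expected, small and within the scatter. For compound 4 a value of 60% is estimated, with a range from 38% to 80%.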

Compound 4, percent growth inhibition at one concentration: 83.5%
Beside the measured number, compound 4's estimate is 23.5 percentage points below it, outside the stated range (above it).
By their numbers in this assay, from the lowest: compounds 3 and 2 (each within the scatter of the next); then compound 1; then compound 4.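

Within this assay piperidin-1-yl in place of thiomorpholin-4-yl on a thiocarbonyl carbon gives a number 15.9 percentage points higher from compound 1 to compound 4 (beyond the scatter) and provides the first direct reading of this position. The ring sulfur of compound 1 is therefore not required for growth inhibition on this core, and this position responds to a change of one ring atom. Nothing given here explains the rise. On these data alone, whether piperidin-1-yl brings a similar step on the core of compound 3 remains open. So does the outcome with morpholin-4-yl or an open-chain diethylamino group at this position.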